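A few compounds are considered here, and "the series" means these few. Any claim that something is new, unique, unknown or untested is made for them only; others in the source may bear on it.

Compound 1 `Cc1cccc(-c2noc([C@H](C)NC(=O)c3cc(C4CC4)nn3C)n2)c1` gives 167 nM in an assay on T-REx-293 cells for inhibition of potassium channel subfamily T member 1 (Homo sapiens), read by patch clamp; on this read-out lower numbers stand for stronger inhibition and higher numbers for weaker inhibition.
Compound 2 `C[C@H](NC(=O)c1cc(C2CC2)nn1C)c1nc(-c2ccccc2)no1` gives 11400 nM.
Compound 3 `C[C@H](NC(=O)c1cc(C(F)(F)F)nn1C)c1nc(-c2ccncc2)no1` gives 5250 nM.

In this assay compound 3 stands second highest of the three numbers, below compound 2 and well above compound 1. Compound 4 `C[C@H](NC(=O)c1cc(C(F)(F)F)nn1C)c1nc(-c2ccnc(C(F)F)c2)no1` is the untested member of the set; it differs from compound 3 by difluoromethyl in place of hydrogen on an aromatic carbon. Among the measured compounds shown here, the single measured step that bears on this change is a 68-fold higher number from compound 1 to compound 2 (1.83 log units; beyond the scatter), a large move that concerns a different group on a different aromatic ring of the series, so it gives a direction rather than a size. A moderate step towards a lower number is therefore expected, well short of that one. Compound 4 is expected at 2500 nM with a range of 800 nM to 8000 nM. The step is expected to be a 2.1-fold lower number from compound 3 to compound 4 (0.32 log units; beyond the scatter).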

Compound 4, half-maximal inhibitory concentration: 61 nM
For compound 4 the middle estimate is 41-fold (1.61 log units) above the measured one; the whole stated range lies above it.
By their numbers in this assay, from the lowest: compound 4; then compound 1; then compound 3; then compound 2.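

On the six-membered aromatic ring with 1 nitrogen, the carbon next to the ring nitrogen proves highly sensitive to substitution: in this assay difluoromethyl in place of hydrogen gives an 86-fold lower number from compound 3 to compound 4 (1.93 log units; beyond the scatter) as a large step. Among the compounds shown here, the earlier step, a 68-fold higher number from compound 1 to compound 2 (1.83 log units; beyond the scatter) for hydrogen in place of methyl, concerned a different aromatic ring, so this is the first sign of a large response on this ring. No measurement at hand explains the step.

As far as these compounds go, whether fluorine is needed remains open: methyl, trifluoromethyl, methoxy or an amine at this place could test it. From the compounds shown here alone, the effect of moving difluoromethyl elsewhere on this ring also remains open.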